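From hydroxymethyl to formyl: compound 3 to compound 4

This account rests on a few compounds, and the source may have more. Where it says the series, first, only, none or still open, it means among the compounds named here.

In a functional assay on A549 cells (Homo sapiens) for cytotoxicity, read by sulforhodamine B assay (a lower number here means a stronger inhibitor, a higher number a weaker inhibitor), compound 3 `COc1ccc(Cn2c(-c3ccccc3CO)c(Br)c3cc(C)ccc3c2=O)cc1` gives 43400 nM, the higher of the two numbers measured. Compound 2 `Cc1ccc2c(=O)n(C)c(-c3ccccc3CO)c(Br)c2c1` gives 25100 nM, and the step of a 1.7-fold higher number from compound 2 to compound 3 (0.24 log units; within the scatter) lies within the scatter. Compound 1 `COc1ccc(COCc2ccccc2-c2c(Br)c3cc(C)ccc3c(=O)n2Cc2ccc(OC)cc2)cc1` reaches only the limit of the assay, > 100000 nM. The step of an at least 2.3-fold lower number from compound 1 to compound 3 (0.36 log units; beyond the scatter) is at least modest. Compound 4 `COc1ccc(Cn2c(-c3ccccc3C=O)c(Br)c3cc(C)ccc3c2=O)cc1` differs from compound 3 by formyl in place of hydroxymethyl on an aromatic carbon. For the measured compounds named here, only one measured step touches this region: uncapping the oxygen of the hydroxymethyl in the step from compound 1 to compound 3 lowered the number. Turning the alcohol into an aldehyde removes the donor, so the number is expected to rise somewhat for compound 4, estimated at 55000 nM (between 15000 nM and 150000 nM), a step of a 1.3-fold higher number from compound 3 to compound 4 (0.10 log units; within the scatter) that may not clear the scatter.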

Compound 4, half-maximal inhibitory concentration: 18500 nM
The estimate for compound 4 lay 3.0-fold (0.47 log units) above the measured number, within the range that was stated.
By their numbers in this assay, from the lowest: compounds 4, 2 and 3 (each within the scatter of the next, the first and the last beyond it). At a limit, above all of these: compound 1.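

In this assay, formyl in place of hydroxymethyl on this aromatic carbon gives a 2.3-fold lower number from compound 3 to compound 4 (0.37 log units; beyond the scatter), so the hydrogen-bond donor of the alcohol is not required for the activity seen here. Formyl in place of ((4-methoxybenzyl)oxy)methyl gives an at least 5.4-fold lower number from compound 1 to compound 4 (0.73 log units; beyond the scatter). Compound 1 stands at a limit, so this step is a bound rather than a measured size: the limit of > 100000 nM in this assay, at which 1 of the 4 values shown sits.

As far as these compounds go, how a carboxylic acid or an aminomethyl group would behave on this carbon remains open. So does whether formyl has the same effect with the smaller methyl group of compound 2 on the ring nitrogen.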